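A few compounds are considered here, and "the series" means these few. Any claim that something is new, unique, unknown or untested is made for them only; others in the source may bear on it.

Compound 3 `CC(C)CCn1nc(-c2cccs2)c(O)c(C2=NS(=O)(=O)c3cc(C4CCCC4=O)ccc3N2)c1=O` stands highest of the three numbers in an in vitro ADME assay on microsomes from liver (Homo sapiens) for metabolic stability, tested at 5 uM (a higher number here means that the compound lasts longer, a lower number that the compound disappears faster), at 0.733 h. Compound 2 `CCC(Oc1ccc2c(c1)S(=O)(=O)N=C(c1c(O)c(-c3cccs3)nn(CCC(C)C)c1=O)N2)C(N)=O` gives 0.35 h and compound 1 `CC(C)CCn1nc(-c2cccs2)c(O)c(C2=NS(=O)(=O)c3ccccc3N2)c1=O` gives 0.2 h in this assay. Among the measured compounds shown here, the steps that bear on the next change are a 3.7-fold higher number from compound 1 to compound 3 (0.56 log units; beyond the scatter) and a 2.1-fold higher number from compound 2 to compound 3 (0.32 log units; beyond the scatter); the step of a 1.8-fold higher number from compound 1 to compound 2 (0.24 log units; within the scatter) is smaller. Compound 4 `CC(=O)c1ccc2c(c1)S(=O)(=O)N=C(c1c(O)c(-c3cccs3)nn(CCC(C)C)c1=O)N2` differs from compound 3 by acetyl in place of 2-oxocyclopentyl on an aromatic carbon. Both the 2-oxocyclopentyl gain from compound 1 and from compound 2 were modest, and the acetyl keeps one double bond outside aromatic rings and one hydrogen-bond acceptor but loses the five-membered non-aromatic ring; a modest fall in this assay toward the values of compound 1 and compound 2 is therefore expected. For compound 4 the expected step is a 1.6-fold lower number from compound 3 to compound 4 (0.21 log units; within the scatter), giving an estimate of 0.45 h with a range from 0.22 h to 0.9 h.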

Compound 4, half-life: 0.0717 h
Estimate against measurement, compound 4: 6.3-fold (0.80 log units) above; measured number below the stated range.
By their numbers in this assay, from the lowest: compound 4; then compounds 1 and 2 (each within the scatter of the next); then compound 3.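

In this assay, among the compounds shown here, acetyl in place of hydrogen gives a 2.8-fold lower number from compound 1 to compound 4 (0.45 log units; beyond the scatter) and is the first group at this aromatic carbon to sit under the unsubstituted compound, so a substituent here can move the number either way. Acetyl in place of 2-oxocyclopentyl gives a 10-fold lower number from compound 3 to compound 4 (1.01 log units; beyond the scatter) with the double bond and hydrogen-bond acceptor counts unchanged, so those counts do not track the number, while the large fall goes with loss of the five-membered non-aromatic ring. Acetyl in place of 1-carbamoylpropoxy gives a 4.9-fold lower number from compound 2 to compound 4 (0.69 log units; beyond the scatter) and no measurement at hand explains these falls.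

Open, on these data alone, is whether a cyclopentyl group without the carbonyl, or a propanoyl group with its longer chain, stays near compound 3 or drops toward compound 4.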